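Fluoro for Trifluoromethyl on a Benzyl Ether Side Chain

The compounds below may be only part of what the source reports. "The series", "measured", "known", "first", "only" and "open" are said of these compounds alone.

Three compounds built on a shared core were tested in a functional assay on SW-620 cells (Homo sapiens) for inhibition, read by MTT assay, with a stated time of 48 h; on this read-out higher numbers stand for weaker inhibition and lower numbers for stronger inhibition. Compound 1 `Cc1ccc(COc2ccc(C(=O)NC(=S)Nc3ccc(C)c(-c4nc5ccccc5[nH]4)c3)cc2)cc1` gives 60900 nM in this assay, and compound 2 `O=C(NC(=S)Nc1ccc(Cl)c(-c2nc3ccccc3[nH]2)c1)c1ccc(OCc2ccc(Cl)cc2Cl)cc1` gives 50200 nM. Compound 3 `Cc1ccc(NC(=O)NC(=O)c2ccc(OCc3cccc(C(F)(F)F)c3)cc2)cc1-c1nc2ccccc2[nH]1` gives 9640 nM, the lowest of the three numbers, and its gaps to compound 2 and compound 1 both lie beyond the scatter, so compound 3 is the strongest inhibitor of the set. Compound 4 `Cc1ccc(NC(=O)NC(=O)c2ccc(OCc3cccc(F)c3)cc2)cc1-c1nc2ccccc2[nH]1` has not yet been measured in this assay. It differs from compound 3 by fluoro in place of trifluoromethyl on an aromatic carbon. For the measured compounds named here, no measured pair shows this change, so its effect is unknown. The step of a 1.6-fold higher number from compound 3 to compound 4 (0.19 log units; within the scatter) is expected to be small and upward, probably not beyond the scatter. Compound 4 is therefore estimated at 15000 nM, within a range from 5000 nM to 45000 nM.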

Compound 4, half-maximal inhibitory concentration: 39600 nM
Compound 4: the middle estimate sits 2.6-fold (0.42 log units) below what was measured; low and high end bracket the measured number.
By their numbers in this assay, from the lowest: compound 3; then compounds 4, 2 and 1 (each within the scatter of the next).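

In this assay, for the compounds shown here, fluoro in place of trifluoromethyl gives a 4.1-fold higher number from compound 3 to compound 4 (0.61 log units; beyond the scatter), the first step in the set that can be read at a single place. It shows that the group on this aromatic carbon of the benzyl ether side chain matters, with 3-(trifluoromethyl)benzyl giving the lower number of the two. Nothing available explains why the number rises with this change. As far as these compounds go, it remains open how a nitrile or a methoxy group would fare at this place, and whether hydrogen there would sit closer to compound 3 or compound 4.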